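The source may hold more compounds than are shown below. What is called first, only, known or untested is meant among the compounds shown, and "the series" means these compounds.

Compounds measured so far:

compound 1 `COc1ccc(Cc2cc(-c3cccs3)nn(CC(=O)Nc3ccc(Br)cc3)c2=O)cc1` — > 50000 nM in an assay on HL-60 cells for agonist activity at N-formyl peptide receptor 3 (Homo sapiens), read by calcium flux; a higher number here means that more compound is needed for the effect, a lower number that less compound is needed
compound 2 `COc1cccc(Cc2cc(-c3cccs3)nn(CC(=O)Nc3ccc(F)cc3)c2=O)c1` — > 50000 nM in this assay
compound 3 `COc1ccc(Cc2cc(-c3ccc(C)cc3)nn(CC(=O)Nc3ccc(Br)cc3)c2=O)cc1` — > 50000 nM in this assay

Compound 2 stands on the shared core with a thiophen-2-yl group and a 3-methoxybenzyl group. In this assay compound 2 gives > 50000 nM, which is a limit of the assay and not a number. Compound 1 likewise gives a limit, > 50000 nM. Compound 3 also gives a limit, > 50000 nM. Thus the limit of > 50000 nM in this assay, at which 3 of the 3 values shown sit: no compound shown has a readable number.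

Compound 4 `COc1cccc(Cc2cc(-c3ccc(F)cc3)nn(CC(=O)Nc3ccc(F)cc3)c2=O)c1` differs from compound 2 in one place: 4-fluorophenyl in place of thiophen-2-yl on an aromatic carbon. For the measured compounds named here, the only measured step that bears on this change is the one from compound 1 to compound 3, where a 4-methylphenyl group replaces the thiophen-2-yl group on an aromatic carbon: a step that the two limits leave unreadable from compound 1 to compound 3. Going by the values given here, since both ends of that step are limits, its size cannot be read, and it offers no direction for the step from compound 2 to compound 4.

With every value shown sitting at the limit, compound 4 is expected to remain weak in this assay, most likely again reported as a limit; the estimate for compound 4 is 80000 nM (range 30000 nM to 300000 nM). The step that this estimate means, from compound 2 to compound 4, is expected to be a step that the limit leaves unreadable from compound 2 to compound 4, that is, none beyond the scatter.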

Compound 4, half-maximal effective concentration: > 50000 nM
Compound 4 was reported as a limit (the forecaster's own chance of this, stated with the estimate: 85%); the middle value lies beyond the limit too.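

Compound 2 and compound 4 are both reported only as limits in this assay, and the size of the change from thiophen-2-yl to 4-fluorophenyl between them cannot be read. The compounds shown leave open which change on the shared core, if any, would give a readable number, since none yet stands clear of this limit: the limit of > 50000 nM in this assay, at which 4 of the 4 values shown sit.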